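The source may hold more compounds than are shown below. What is called first, only, known or untested is meant among the compounds shown, and "the series" means these compounds.

Measured so far:
compound 1 `O=C(O)c1ccc(C(=O)/C(=C\c2ccc(F)c([N+](=O)[O-])c2)SCc2ccc(Cl)cc2Cl)cc1` — < 1000 ug/mL
compound 2 `O=C(O)c1ccc(C(=O)/C(=C\c2ccc(Cl)c([N+](=O)[O-])c2)SCc2ccccc2F)cc1` — < 1000 ug/mL
compound 3 `O=C(O)c1ccc(C(=O)/C(=C\c2ccc(Br)c([N+](=O)[O-])c2)SCc2ccc(Br)cc2)cc1` — < 1000 ug/mL

In a physicochemical assay for solubility (on this read-out lower numbers stand for lower solubility and higher numbers for higher solubility), compound 1 gives < 1000 ug/mL, which is a limit of the assay and not a number. Compound 2 gives < 1000 ug/mL, likewise a limit. Compound 3 gives < 1000 ug/mL, also a limit. Among the compounds with values here, every value shown therefore sits at the limit of < 1000 ug/mL in this assay, at which 3 of the 3 values shown sit, so compound 1 cannot be placed above or below compound 2 or compound 3, and no step between measured compounds can be read from these three.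

Compound 4 `O=C(O)c1ccc(C(=O)/C(=C\c2ccc(F)c([N+](=O)[O-])c2)SCc2ccc(Cl)cc2)cc1` has not yet been measured in this assay. It differs from compound 1 by hydrogen in place of chloro on an aromatic carbon.

Within the data shown here, with no measured step and all three values at a limit, the expected step that the limit leaves unreadable from compound 1 to compound 4 is small and not beyond the scatter in either direction, and the read-out for compound 4 is expected to come back as a limit again due to the limit of < 1000 ug/mL in this assay, at which 3 of the 3 values shown sit. For compound 4 the estimate in this assay is 300 ug/mL, with a range from 30 ug/mL to 1000 ug/mL, the number itself being an expectation rather than a reading.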

Compound 4, solubility: < 1000 ug/mL
Compound 4: a limit, no number; the forecaster's own chance of this, stated with the estimate: 85%; the middle value does not contradict the limit.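

In this assay compound 4 gives < 1000 ug/mL, a limit and not a number. Within the data shown here, no step from compound 1 to compound 4 can be read, because both compounds sit at the same limit: the limit of < 1000 ug/mL in this assay, at which 4 of the 4 values shown sit. The compounds shown leave open whether hydrogen in place of chloro on an aromatic carbon moves the read-out at all.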